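Adding a Cyano Group to a Tolerated Compound

This account rests on a few compounds, and the source may have more. Where it says the series, first, only, none or still open, it means among the compounds named here.

Compound 1 `CCCCOC(=O)Nc1ccc(CN2N=C(c3ccc(F)cc3)C3C=CC=CC3C2=O)cc1` and compound 2 `CN(C)CCCCOC(=O)Nc1ccc(Cn2nc(-c3ccccc3)c3ccccc3c2=O)cc1` were both tested in an ADME assay on Huh-7 cells (Homo sapiens) for cytotoxicity, read by MTT assay, with a stated time of 48 h; a higher number here means that more compound is tolerated, a lower number that less compound is tolerated. Compound 1 gives 19500 nM, and compound 2 gives 16000 nM. The smaller number belongs to compound 2, yet the gap is within the scatter, so the two cannot be told apart. Compound 3 `CN(C)CCCCOC(=O)Nc1ccc(Cn2nc(-c3ccccc3C#N)c3ccccc3c2=O)cc1` has not yet been measured; it differs from compound 2 by cyano in place of hydrogen on an aromatic carbon. Within the data shown here, no step between two measured compounds is known here. The expected step of a 1.1-fold lower number from compound 2 to compound 3 (0.03 log units; within the scatter) is therefore taken as none beyond the scatter. Compound 3 is estimated at 15000 nM, with a likely range from 7000 nM to 32000 nM.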

Compound 3, half-maximal cytotoxic concentration: 90700 nM
The estimate for compound 3 lay 6.0-fold (0.78 log units) below the measured number, outside the stated range (above it).
By their numbers in this assay, from the lowest: compounds 2 and 1 (each within the scatter of the next); then compound 3.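

Changing phenyl to 2-cyanophenyl is the only single-place change among these compounds, and in this assay it gives a 5.7-fold higher number from compound 2 to compound 3 (0.75 log units; beyond the scatter). This shows that the aromatic carbon ortho to a large group is not indifferent to substitution: with cyano in place of hydrogen there, more compound is tolerated. The data shown give no reason for this rise.

As far as these compounds go, whether the rise is specific to cyano remains open. A compound with fluorine, a methoxy group or an amine at this carbon would show whether other groups raise the number too.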